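Working notes: a side chain on compound 2

The source may report more compounds than this note shows. Statements on the series, on what has been measured and on what is new or still open speak of the compounds shown alone.

- compound 1 `Cc1cn(C)c(C)c(O)c1=O`: -0.51
- compound 2 `COc1c[nH]ccc1=O`: -0.85

Only these two compounds have been measured so far in a physicochemical assay for lipophilicity, using the shake flask method, measured as octanol-water partition; a higher number here means a more lipophilic compound, a lower number a more polar compound. Compound 2 stands lowest at -0.85, and compound 1 gives -0.51, a gap beyond the scatter of repeated measurements.

The next compound is compound 3 `COc1c[nH]cc(CN(C)C)c1=O`, which departs from compound 2 in one place: (dimethylamino)methyl in place of hydrogen on an aromatic carbon. The (dimethylamino)methyl replaces a hydrogen on an aromatic carbon of the six-membered aromatic ring with 1 nitrogen. This carbon is ortho to a group of 1 heavy atom, two atoms from the ring nitrogen and meta to a methoxy group.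

Among the compounds with values here, no measured pair shows a change in one place, so the data give no direct guide to the size of this step. A small downward move in this assay is expected, possibly none beyond the scatter, and the estimated step is a number 0.20 log units lower from compound 2 to compound 3 (within the scatter). The range is kept wide for that reason. For compound 3 the expected value is -1.05, with an estimated range from -1.7 to -0.4.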

Compound 3, partition coefficient: -0.85
Compound 3: the middle estimate sits 0.20 log units below what was measured; the measured number falls inside the stated range.
By their numbers in this assay, from the lowest: compounds 2 and 3 (each within the scatter of the next); then compound 1.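

In this assay, within the data shown here, the first step with a change in one place reads no change at the digits printed from compound 2 to compound 3 (within the scatter). Among these compounds, at this aromatic carbon, ortho to a group of 1 heavy atom and two atoms from the ring nitrogen, (dimethylamino)methyl in place of hydrogen therefore adds 4 heavy atoms, including 1 hydrogen-bond acceptor, with no shift in the read-out, which no earlier step could show. No measurement at hand accounts for this flat step, so it stands as an observation on this single pair.

As far as these compounds go, it remains open whether a longer chain such as 2-(dimethylamino)ethyl, a cyclic amine such as morpholin-4-ylmethyl, or a carboxylic acid at the same carbon would also leave the number in this assay unchanged. Also open, from the compounds shown here alone, is whether (dimethylamino)methyl would give the same flat step if the methoxy group were replaced by a hydroxy group.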